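Swapping phenoxy for methylsulfonyl on a shared core

This account rests on a few compounds, and the source may have more. Where it says the series, first, only, none or still open, it means among the compounds named here.

- compound 1 `CCOC(=O)c1c(-c2cccc(-c3ccccc3)c2)[nH]c2cc(OC)ccc2c1=O` gives > 22000 nM as a limit
- compound 2 `CCOC(=O)c1c(-c2cccc(OCC(C)C)c2)[nH]c2cc(OC)ccc2c1=O` gives > 22000 nM as a limit
- compound 3 `CCOC(=O)c1c(-c2cccc(Oc3ccccc3)c2)[nH]c2cc(OC)ccc2c1=O` gives > 22000 nM as a limit

In an ADME assay on HEK293 cells (Homo sapiens) for cytotoxicity, read by luminescence, with a stated time of 72 h (a lower number here means that less compound is needed, a higher number that more compound is needed for the effect), compound 3 gives > 22000 nM as a limit, not as a number. Among the measured compounds shown here, the series so far rests on the limit of > 22000 nM in this assay, at which 3 of the 3 values shown sit, and so its compounds cannot be ranked.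

Compound 4 `CCOC(=O)c1c(-c2cccc(S(C)(=O)=O)c2)[nH]c2cc(OC)ccc2c1=O` keeps the shared core and changes one group: methylsulfonyl in place of phenoxy on an aromatic carbon. In words, this is methylsulfonyl in place of phenoxy on an aromatic carbon, meta to a large group.

For the measured compounds named here, three measured steps bear on this change, as each alters the group at that place. They are a step that the two limits leave unreadable from compound 1 to compound 2, a step that the two limits leave unreadable from compound 1 to compound 3 and a step that the two limits leave unreadable from compound 2 to compound 3, and none has a size that can be read. No size can therefore be carried over to compound 4, and methylsulfonyl itself has not yet been measured in this series.

Compound 3 sits at > 22000 nM and this limit is the only anchor for an expectation. No step beyond the scatter is expected in this assay, and no direction can be given. The expected change is a step that the limit leaves unreadable from compound 3 to compound 4 and a further limit is the likeliest report. Compound 4 is estimated at 25000 nM, with an expected range from 12000 nM to 50000 nM as its span.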

Compound 4, half-maximal effective concentration: > 22000 nM
Compound 4 ended at the assay's limit; the forecaster's own chance of this, stated with the estimate: 85%; the middle value lies beyond the limit too.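

Compound 4 ends at a limit of the assay rather than a number, as do compound 1, compound 2 and compound 3, so no step among these compounds can be read: the limit of > 22000 nM in this assay, at which 4 of the 4 values shown sit.

The compounds shown leave open how the four groups rank in this assay, and at what concentration each compound would reach its half-maximal effect.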